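Amide chain length at the pyridine amide in the series

The source may hold more compounds than are shown below. What is called first, only, known or untested is meant among the compounds shown, and "the series" means these compounds.

Measured compounds:
compound 1 `CCCC(=O)Nc1cc(Oc2ccc(Nc3nccc4[nH]cc(-c5ccc(F)cc5)c(=O)c34)cc2F)ccn1`: 64.6%
compound 2 `Cn1cc(-c2ccc(F)cc2)c(=O)c2c(Nc3ccc(Oc4ccnc(NC(=O)C5CC5)c4)c(F)c3)nccc21`: 30.9%
compound 3 `CC(=O)Nc1cc(Oc2ccc(Nc3nccc4[nH]cc(-c5ccc(F)cc5)c(=O)c34)cc2F)ccn1`: 77.1%

Among the compounds with values here, in a functional assay on MKN-45 cells (Homo sapiens) for antiproliferative activity, read by MTT assay, with a stated time of 72 h, tested at 10 uM (on this read-out higher numbers stand for more inhibition at the one concentration tested (going by the name of the read-out) and lower numbers for less inhibition), compound 3 gives the highest of the three numbers; compound 1 stands beyond the scatter below it, and compound 2 stands far lower still, with no single-point step to compound 3 available. Within the data shown here, the one relevant step is a number 12.5 percentage points higher from compound 1 to compound 3 (beyond the scatter), which shows that shortening the chain on the carbonyl raised inhibition by a modest margin. Compound 4 `CCCCC(=O)Nc1cc(Oc2ccc(Nc3nccc4[nH]cc(-c5ccc(F)cc5)c(=O)c34)cc2F)ccn1` goes the other way: propyl in place of hydrogen on a saturated chain carbon bound to a carbonyl carbon. Extending the chain further than in compound 1 is therefore expected to lower inhibition in this assay, by a step of similar or somewhat larger size than the step from compound 1 to compound 3, reversed. For compound 4 the estimate is 58%, within 42% to 72%, corresponding to a number 19.1 percentage points lower from compound 3 to compound 4 (beyond the scatter).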

Compound 4, a percentage reported as inhibition, at one concentration (the size of the read-out at that concentration, not a potency): 62.7%
Compound 4: middle estimate off by 4.7 percentage points, on the low side; the range from low to high includes it.
By their numbers in this assay, from the lowest: compound 2; then compounds 4 and 1 (each within the scatter of the next); then compound 3.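

In this assay the longer chain gives a number 14.4 percentage points lower from compound 3 to compound 4 (beyond the scatter) and adding one more carbon to the chain of compound 1 gives a number 1.9 percentage points lower from compound 1 to compound 4 (within the scatter). Across compound 3, compound 1 and compound 4, the drop therefore appears on leaving the acetamido group and does not grow from compound 1 to compound 4. No measurement here accounts for this.

Still open, from the compounds shown here alone, is how a chain longer than butyl, a branched chain or a chain ending in an amine or a carboxylic acid would read at this position.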